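The source may hold more compounds than are shown below. What is called first, only, known or untested is meant among the compounds shown, and "the series" means these compounds.

Of the compounds shown here, three of a shared core have been tested in a functional assay on A549 cells (Homo sapiens) for antiproliferative activity, read by MTT assay, with a stated time of 24 h; on this read-out lower numbers stand for stronger inhibition and higher numbers for weaker inhibition. Compound 1 `O=C(NNc1cccc(Cl)c1)c1ccc(NS(=O)(=O)c2cnc(O)nc2O)cc1` gives 7290 nM in this assay. Compound 2 `Cc1cccc(NNC(=O)c2cccc(NS(=O)(=O)c3cnc(O)nc3O)c2)c1` reaches only the limit of this assay, reported as > 20000 nM, so its result is not a number. Compound 3 `Cc1cccc(NNC(=O)c2ccccc2NS(=O)(=O)c2cnc(O)nc2O)c1` likewise sits at the limit, > 20000 nM. Compound 2 thus stands at the edge of what this assay can report, together with compound 3, while compound 1 is the only one of the three with a measured number; the limit of > 20000 nM in this assay, at which 2 of the 3 values shown sit, marks the point at which those two sit. For the measured compounds named here, no step between two measured compounds is available here, so no measured change in potency can be read from them.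

Compound 4 `O=C(NNC(=O)c1cccc(NS(=O)(=O)c2cnc(O)nc2O)c1)c1ccc(F)cc1` has not been tested. It differs from compound 2 in one place: (4-fluorophenyl)carbonyl in place of 3-methylphenyl on an amine nitrogen. Compound 2 sits at a limit, so the step to compound 4 can only be expected, not derived, and the estimate is wide. The step that this estimate means, an at least 1.3-fold lower number from compound 2 to compound 4 (0.12 log units; that floor lies within the scatter), is expected to be small or none beyond the scatter. Compound 4 is expected to give about 15000 nM in this assay, with a range from 5000 nM to 40000 nM.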

Compound 4, half-maximal inhibitory concentration: > 20000 nM
Compound 4: only a limit was reported; the forecaster's own chance of this, stated with the estimate: 50%; at least 1.3-fold (0.12 log units) between middle value and limit.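

Compound 2 and compound 4 each give only a limit rather than a number, so the step between them cannot be read: the limit of > 20000 nM in this assay, at which 3 of the 4 values shown sit.

The compounds shown leave open whether (4-fluorophenyl)carbonyl in place of 3-methylphenyl on an amine nitrogen changes the result in this assay at all, and if so, by how much.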